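Cyclobutyl to Propargyl on a Quaternary Nitrogen

The source may report more compounds than this note shows. Statements on the series, on what has been measured and on what is new or still open speak of the compounds shown alone.

Compound 1, `C[N+](C)(CCCC(=O)[O-])Cc1ccccc1`, gives > 1000000 nM in an assay for inhibition of gamma-butyrobetaine dioxygenase (Homo sapiens), read by HPLC, with stated times of 15 min and 30 min; on this read-out lower numbers stand for stronger inhibition and higher numbers for weaker inhibition; this is a limit of the assay, not a number.
Compound 2, `C[N+](C)(CCCC(=O)[O-])C1CCC1`, gives 810 nM in this assay.
Compound 3, `C[N+](C)(CCCC(=O)[O-])C1CCCC1`, gives > 1000000 nM in this assay; this too is a limit of the assay.

Going by the values given here, compound 2 therefore stands alone as the only measured number here; the two other values shown are limits, as the limit of > 1000000 nM in this assay, at which 2 of the 3 values shown sit, records. Among the compounds with values here, no step between two measured compounds can be drawn, so the account rests on compound 2 and on the structural change to compound 4.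

Compound 4, `C#CC[N+](C)(C)CCCC(=O)[O-]`, differs from compound 2 in one place: propargyl in place of cyclobutyl on an amine nitrogen. Nothing measured here shows what such a change does, and the two compounds that carry groups other than cyclobutyl on that nitrogen both sit at the limit.

For compound 4 a weakening beyond the scatter is expected, with a considerable chance that only a limit is returned; the expected step is a 7.4-fold higher number from compound 2 to compound 4 (0.87 log units; beyond the scatter). The estimated value for compound 4 in this assay is 6000 nM, in a range from 500 nM to 200000 nM.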

Compound 4, half-maximal inhibitory concentration: 1400 nM
Compound 4: middle estimate off by 4.3-fold (0.63 log units), on the high side; low and high end bracket the measured number.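

In this assay, going by these compounds alone, propargyl in place of cyclobutyl on an amine nitrogen gives a 1.7-fold higher number from compound 2 to compound 4 (0.24 log units; within the scatter), the first step that can be read at this position. A measured number at this nitrogen is therefore not confined to cyclobutyl: compound 4 carries no ring, has a triple bond outside aromatic rings, and still sits within the scatter of compound 2, so this change separates the two compounds by no more than repeated measurements would. Not every group on this nitrogen returns a number, however, as compound 1 and compound 3 remain limits of the assay, and these limits are recorded here as: the limit of > 1000000 nM in this assay, at which 2 of the 4 values shown sit.

The compounds shown leave open whether a saturated propyl group, an allyl group or a cyclopropyl ring on the same nitrogen would also give a number, and so whether the triple bond of compound 4 has any part in its value. They also leave open how a longer chain carrying a triple bond, or a propargyl group bearing a methyl group, would read in this assay.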